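The source may report more compounds than this note shows. Statements on the series, on what has been measured and on what is new or still open speak of the compounds shown alone.

Compound 1 `CNc1ncc2c(-c3ccc(N4CCNCC4)nc3)nn(CC3CCCC3)c2n1` gives 640 nM in an assay for inhibition of tyrosine-protein kinase Mer (Homo sapiens), read by 33P incorporation, in the presence of a further agent that is not named here (a lower number here means a stronger inhibitor, a higher number a weaker inhibitor), the lowest of the two numbers available. Compound 2 `CNc1ncc2c(-c3ccc(N4CCNCC4)nc3)nn(CC3OCCO3)c2n1` gives 6200 nM, and the step from compound 1 to compound 2 a 9.7-fold higher number from compound 1 to compound 2 (0.99 log units; beyond the scatter) concerns only the group on the saturated chain carbon bound to an aromatic nitrogen. Compound 3 `CNc1ncc2c(-c3ccc(N4CCN(C(=O)C(C)(C)C)CC4)nc3)nn(CC3CCCC3)c2n1` differs from compound 1 elsewhere: (tert-butyl)carbonyl in place of hydrogen on an amine nitrogen in a ring. Among the measured compounds shown here, no measured step touches this ring nitrogen, so nothing measured bears directly on the change. Compound 3 is therefore expected to stay near compound 1, with at most a modest rise, a 1.9-fold higher number from compound 1 to compound 3 (0.27 log units; within the scatter), estimated at 1200 nM in the range 400 nM to 4000 nM.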

Compound 3, half-maximal inhibitory concentration: > 10000 nM
Compound 3: only a limit was reported; the forecaster's own chance of this, stated with the estimate: 5%; at least 8.3-fold (0.92 log units) between middle value and limit.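

In this assay, (tert-butyl)carbonyl in place of hydrogen on the amine nitrogen in the ring gives a large loss (an at least 15-fold higher number from compound 1 to compound 3 (1.19 log units; beyond the scatter)). This shows that the ring nitrogen, which compounds 1 and 2 left unchanged, does not accept every group while the rest of compound 1 stays the same. The value of compound 3 is a limit, not a number: (the limit of > 10000 nM in this assay, at which 1 of the 3 values shown sits). As far as these compounds go, the true size of the step therefore stays unknown. From the compounds shown here alone, whether an acetyl or a methyl group on this nitrogen would stay near compound 1 also remains open.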